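Varying the cyclic amine on the shared core

A few compounds are considered here, and "the series" means these few. Any claim that something is new, unique, unknown or untested is made for them only; others in the source may bear on it.

Measured in a functional assay on NCI-H1975 cells (Homo sapiens) for inhibition, read by CellTiter-Glo, with a stated time of 72 h; a lower number here means a stronger inhibitor of growth, a higher number a weaker inhibitor of growth:
compound 1 `C=CC(=O)Nc1cc(Nc2ncc(Cl)c(Nc3ccccc3S(=O)(=O)C(C)C)n2)c(OC)cc1N1CCC(N2CCN(C)CC2)CC1`: 23 nM
compound 2 `C=CC(=O)Nc1cc(Nc2ncc(Cl)c(Nc3ccccc3S(=O)(=O)C(C)C)n2)c(OC)cc1N1CCN(C)CC1`: 43 nM
compound 3 `C=CC(=O)Nc1cc(Nc2ncc(Cl)c(Nc3ccccc3S(=O)(=O)C(C)C)n2)c(OC)cc1N1CCCN(C)CC1`: 15 nM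

Compound 3 gives the lowest of the three numbers in this assay. Compound 1 sits within the scatter of compound 3, so no order between those two is claimed. Compound 2 stands further off: a 2.9-fold lower number from compound 2 to compound 3 (0.46 log units; beyond the scatter).

Compound 4 `C=CC(=O)Nc1cc(Nc2ncc(Cl)c(Nc3ccccc3S(=O)(=O)C(C)C)n2)c(OC)cc1N1CCN(C2CCCCC2)CC1` is the next member. The change from compound 3 is 4-cyclohexylpiperazin-1-yl in place of 4-methyl-1,4-diazepan-1-yl on an aromatic carbon.

Going by the values given here, only one measured step concerns the same cyclic amine, the modest one from compound 2 to compound 3, and it swapped ring size rather than the group on the distal nitrogen. Compound 1 and compound 3 show that a larger terminal group on the ring nitrogen can sit within the scatter of the methyl-bearing seven-membered ring. Among the compounds with values here, no measured step tracks a cyclohexyl group. The expectation for compound 4 in this assay is therefore no step beyond the scatter, with a wide range: a 1.7-fold higher number from compound 3 to compound 4 (0.22 log units; within the scatter). Compound 4 is estimated at 25 nM, between 8 nM and 80 nM.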

Compound 4, concentration for 50% growth inhibition: 77 nM
Beside the measured number, compound 4's estimate is 3.1-fold (0.49 log units) below it; low and high end bracket the measured number.
By their numbers in this assay, from the lowest: compounds 3, 1, 2 and 4 (each within the scatter of the next, the first and the last beyond it).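

In this assay, 4-cyclohexylpiperazin-1-yl in place of 4-methyl-1,4-diazepan-1-yl gives a 5.1-fold higher number from compound 3 to compound 4 (0.71 log units; beyond the scatter), while cyclohexyl in place of methyl on the ring amine nitrogen gives a 1.8-fold higher number from compound 2 to compound 4 (0.25 log units; within the scatter), so this assay does not separate those two groups on the six-membered ring. The step from compound 3 changes ring size and the nitrogen group together, and of the two single changes only the ring change, a 2.9-fold lower number from compound 2 to compound 3 (0.46 log units; beyond the scatter), lies beyond the scatter, which points to ring size as the change that counts here. Nothing available explains these differences.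

A 4-cyclohexyl-1,4-diazepan-1-yl group would show whether the seven-membered ring keeps its number with the larger group on nitrogen. Also open, as far as these compounds go, is how a hydroxyethyl or acetyl group on that nitrogen would read.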